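Adding a Methyl Group: One Change on Two Cores

A few compounds are considered here, and "the series" means these few. Any claim that something is new, unique, unknown or untested is made for them only; others in the source may bear on it.

Compound 2 `COc1cc(OC)c2sc(-c3ccc(N/C=C\C(=O)c4ccc(OC)c([N+](=O)[O-])c4)cc3)nc2c1` and compound 1 `COc1cc(OC)c2sc(-c3ccc(N/C=C\C(=O)c4ccc(OC)c([N+](=O)[O-])c4)c(C)c3)nc2c1` share one core, and compound 1 carries methyl in place of hydrogen on an aromatic carbon. In a functional assay on A549 cells (Homo sapiens) for antiproliferative activity, read by sulforhodamine B assay, with a stated time of 48 h (a lower number here means a stronger inhibitor, a higher number a weaker inhibitor), compound 2 gives 5800 nM, while compound 1 gives 12100 nM, which is a 2.1-fold higher number from compound 2 to compound 1 (0.32 log units; beyond the scatter). Compound 3 `COc1ccc2nc(-c3ccc(N/C=C\C(=O)c4cc(OC)c(OC)c([N+](=O)[O-])c4)cc3)sc2c1` has the same atoms as compound 2 joined differently; the difference between the two cores is not broken down here. In this assay compound 3 gives 21600 nM. Compound 4 `COc1ccc2nc(-c3ccc(N/C=C\C(=O)c4cc(OC)c(OC)c([N+](=O)[O-])c4)c(C)c3)sc2c1` applies the same kind of change to the core of compound 3: methyl in place of hydrogen on an aromatic carbon. The surroundings differ slightly: in compound 1 the methyl is meta to a large group, whereas in compound 4 it is meta to a 6-methoxy-1,3-benzothiazol-2-yl group. A step of similar size is expected, a 1.9-fold higher number from compound 3 to compound 4 (0.27 log units; within the scatter), because it mirrors a 2.1-fold higher number from compound 2 to compound 1 (0.32 log units; beyond the scatter). Compound 4 is therefore estimated at 40000 nM, most likely between 15000 nM and 90000 nM.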

Compound 4, half-maximal inhibitory concentration: 22100 nM
The estimate for compound 4 lay 1.8-fold (0.26 log units) above the measured number; low and high end bracket the measured number.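

In this assay, the same methyl change on the second core gives a 1.0-fold higher number from compound 3 to compound 4 (0.01 log units; within the scatter), so on this core the step cannot be told from repeat-measurement noise. Set beside the earlier step, the result on this core does not differ from the one on the first core: the same change on two cores in this assay, a 2.1-fold higher number (0.32 log units; beyond the scatter) from compound 2 to compound 1 and a 1.0-fold higher number (0.01 log units; within the scatter) from compound 3 to compound 4, 2.0-fold (0.31 log units) apart, within the scatter of two such steps. This fits a single methyl step shared by both cores, but two pairs cannot show that the change carries over reliably to other cores, nor explain why only the earlier step lies beyond the scatter.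

The compounds shown leave open whether a larger or different group at this place, such as ethyl, chlorine or an amine, would give matching steps on both cores. They also leave open how the methyl step would behave on a third core.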